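Two Limits and an Unmeasured Vinylcarbonyl Analogue

The source may hold more compounds than are shown below. What is called first, only, known or untested is meant among the compounds shown, and "the series" means these compounds.

Measured in an ADME assay on BaF3 cells (Mus musculus) for cytotoxicity, read by CellTiter-Glo and CCK-8 assay, with a stated time of 72 h; a lower number here means a stronger inhibitor of growth, a higher number a weaker inhibitor of growth:
- Compound 1 `Cc1ccc(NC(=O)c2ccc(CNCCN(C)C)cc2)cc1Nc1nccc(-c2cccnc2)n1`: > 10000 nM, a limit of the assay
- Compound 2 `Cc1ccc(NC(=O)c2ccc(CN(CCN(C)C)C(=O)C(C)C)cc2)cc1Nc1nccc(-c2cccnc2)n1`: > 10000 nM, a limit of the assay

Compound 2 stands at the limit of > 10000 nM in this assay, at which 2 of the 2 values shown sit. Among the measured compounds shown here, the only measured step is a step that the two limits leave unreadable from compound 1 to compound 2, so it offers no size to carry forward.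

Compound 3 `C=CC(=O)N(CCN(CC)CC)Cc1ccc(C(=O)Nc2ccc(C)c(Nc3nccc(-c4cccnc4)n3)c2)cc1` differs from compound 2 by (2-(diethylamino)ethyl)(vinylcarbonyl)amino in place of (2-(dimethylamino)ethyl)(isopropylcarbonyl)amino on a saturated chain carbon bound to an aromatic carbon. With no readable step as a guide, only a small shift in this assay is expected, with growth inhibition staying weak and no firm direction.

The expected change is a number no higher from compound 2 to compound 3 (the limit leaves the size open).

For compound 3 the estimated value is 10000 nM, with an expected range of 3000 nM to 30000 nM.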

Compound 3, concentration for 50% growth inhibition: 5450 nM
The estimate for compound 3 lay 1.8-fold (0.26 log units) above the measured number; low and high end bracket the measured number.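

In this assay, compound 3 is the only compound shown with a measured number, so a change on a saturated chain carbon bound to an aromatic carbon can bring growth inhibition inside the readable range. The steps are an at least 1.8-fold lower number from compound 2 to compound 3 (0.26 log units; that floor lies within the scatter) and an at least 1.8-fold lower number from compound 1 to compound 3 (0.26 log units; that floor lies within the scatter); as floors, they leave the true sizes open. The other two compounds remain at a limit of the assay: the limit of > 10000 nM in this assay, at which 2 of the 3 values shown sit.

As far as these compounds go, the vinylcarbonyl and diethylamino groups enter together, so their separate contributions remain unknown. Also open, from the compounds shown here alone, is how a morpholine in place of the diethylamino group would read.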